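Swapping amino for hydroxy on a side chain

A few compounds are considered here, and "the series" means these few. Any claim that something is new, unique, unknown or untested is made for them only; others in the source may bear on it.

Compound 1 `COc1cc(C(=O)/C=C/c2ccc(O)c(O)c2)cc(OC)c1OC` gives 2600 nM in a functional assay on A549 cells (Homo sapiens) for cytotoxicity, read by fluorescence, with a stated time of 48 h; a lower number here means a stronger inhibitor of growth, a higher number a weaker inhibitor of growth
Compound 2 `COc1ccc(/C=C/C(=O)c2cc(OC)c(OC)c(OC)c2)cc1OCCN` gives 5600 nM in this assay

Compound 2 holds the higher of the two numbers at 5600 nM while compound 1 lies at 2600 nM in this assay and this gap is beyond the scatter. The two compounds differ in more than one place, so the gap cannot be assigned to any single group.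

Compound 3 `COc1ccc(/C=C/C(=O)c2cc(OC)c(OC)c(OC)c2)cc1OCCO` has not yet been measured. It differs from compound 2 in one place only, with hydroxy in place of amino on a saturated chain carbon, two bonds along the chain from an oxygen on an aromatic ring. That turns 2-aminoethoxy to 2-hydroxyethoxy. Going by the values given here, no measured pair shows this exchange, so the guide is indirect. Compound 1 carries no amino group and reads 2600 nM in this assay so a modest move toward a lower number is expected, with no step beyond the scatter. The estimated 1.5-fold lower number from compound 2 to compound 3 (0.17 log units; within the scatter) is therefore small. Compound 3 is estimated at 3800 nM with a range from 1500 nM to 10000 nM as the expected outcome.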

Compound 3, concentration for 50% growth inhibition: 4700 nM
Beside the measured number, compound 3's estimate is 1.2-fold (0.09 log units) below it, and the stated range covers the measured number.
By their numbers in this assay, from the lowest: compounds 1, 3 and 2 (each within the scatter of the next, the first and the last beyond it).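

In this assay, going by these compounds alone, this is the first pair that differs in one place, and it gives a 1.2-fold lower number from compound 2 to compound 3 (0.08 log units; within the scatter). Hydroxy in place of amino on a saturated chain carbon, two bonds along the chain from an oxygen on an aromatic ring, therefore leaves the read-out within the scatter, so in this one assay 2-aminoethoxy and 2-hydroxyethoxy on the shared core cannot be told apart, something the earlier compounds, which differ in more than one place, could not show. Nothing measured here offers an explanation for this result.

The compounds shown leave open whether the side chain matters at all at this position, as a tertiary amine, a carboxylic acid or a longer chain such as 3-aminopropoxy does not appear among them, nor does a plain methoxy group in its place. They also leave open which of the differences between compound 1 and compound 2 accounts for the gap between those two, and whether this exchange would read the same way on another core.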